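Shifting the Chlorine on the Sulfur-Linked Benzyl Group

A few compounds are considered here, and "the series" means these few. Any claim that something is new, unique, unknown or untested is made for them only; others in the source may bear on it.

Of the compounds shown here, two of a shared core have been tested in a functional assay on the whole organism (artery, strain albino) with Rattus norvegicus as the target, with a stated time of 240 min, at a dose of 10 mg/kg by the oral route; a higher number here means more inhibition at the dose given (going by the name of the read-out), a lower number less inhibition. Compound 1, `CC1=C(C(=O)Nc2ccc([N+](=O)[O-])cc2)C(c2ccc(Br)cc2)N=C(SCc2cccc(Cl)c2)N1`, gives 11.8% in this assay. Compound 2, `CC1=C(C(=O)Nc2ccc([N+](=O)[O-])cc2)C(c2cccc([N+](=O)[O-])c2)N=C(SCc2ccccc2Cl)N1`, gives 12.8% in this assay. The number for compound 2 is within the usual scatter of the number for compound 1, so the two measured compounds cannot be told apart on these readings, and both show only modest inhibition at the dose given.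

Compound 3, `CC1=C(C(=O)Nc2ccc([N+](=O)[O-])cc2)C(c2cccc([N+](=O)[O-])c2)N=C(SCc2cccc(Cl)c2)N1`, has not yet been measured in this assay. It keeps every atom of compound 2 but joins them differently: 3-chlorophenyl in place of 2-chlorophenyl on a saturated chain carbon bound to a sulfur. For the measured compounds named here, no measured pair isolates this change, so its effect is not known from the data.

Given that both measured compounds sit close together at low inhibition, the step from compound 2 to compound 3 is expected to be small, a number 0.8 percentage points lower from compound 2 to compound 3 (within the scatter), with no direction that reaches beyond the scatter. Compound 3 is therefore estimated to give 12% in this assay, with a likely range from 3% to 22%.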

Compound 3, a percentage reported as inhibition, in the whole organism at one dose (the size of the read-out at that dose, not a potency): 17.9%
Beside the measured number, compound 3's estimate is 5.9 percentage points below it; the range from low to high includes it.
By their numbers in this assay, from the lowest: compounds 1, 2 and 3 (each within the scatter of the next).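

The pair compound 2 and compound 3 isolates a single change, 3-chlorophenyl in place of 2-chlorophenyl on a saturated chain carbon bound to a sulfur, and in this assay this gives a number 5.1 percentage points higher from compound 2 to compound 3 (within the scatter) on this reading. Compound 1 and compound 3 isolate a second change, 3-nitrophenyl in place of 4-bromophenyl on a saturated ring carbon, which gives a number 6.1 percentage points higher from compound 1 to compound 3 (within the scatter) in the same test. Since neither step clears the scatter, these three compounds cannot be told apart, so neither the placement of the chlorine nor this swap on the ring carbon has been shown to matter in this assay, and no outside evidence bears on either result.

Going by these compounds, whether a plain benzyl group without chlorine, or a longer chain on the sulfur, would move the inhibition beyond the scatter remains open. The same goes for an amine or a carboxylic acid on the ring at the saturated ring carbon, and a reading at a single dose gives no measure of potency for any of these compounds.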